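Methyl added to the phenyl group of compound 1

The source may hold more compounds than are shown below. What is called first, only, known or untested is meant among the compounds shown, and "the series" means these compounds.

In an ADME assay on BJ cells (Homo sapiens) for cytotoxicity, with a stated time of 72 h (a higher number here means that more compound is needed for the effect, a lower number that less compound is needed), compound 1 (`CCc1ccc(-c2nc3c(c(C)nn3-c3ccccc3)c(-c3ccccc3O)c2C#N)cc1`) gives > 20000 nM, which is a limit and not a number. Compound 2 (`COc1ccc(-c2nc3c(c(C)nn3-c3ccccc3)c(-c3ccccc3O)c2C#N)cc1`) gives > 23000 nM, also a limit. Compound 3 (`Cc1nn(-c2ccccc2)c2nc(-c3ccc4ccccc4c3)c(C#N)c(-c3ccccc3O)c12`) gives > 20000 nM, again a limit. Compound 1 therefore cannot be ranked against either neighbour.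

Compound 4 (`CCc1ccc(-c2nc3c(c(C)nn3-c3ccc(C)cc3)c(-c3ccccc3O)c2C#N)cc1`) differs from compound 1 by methyl in place of hydrogen on an aromatic carbon, phenyl to 4-methylphenyl. The measured steps are a step that the two limits leave unreadable from compound 1 to compound 2, a step that the two limits leave unreadable from compound 1 to compound 3 and a step that the two limits leave unreadable from compound 2 to compound 3. None has a readable size, and all three change a different group from the phenyl altered here, so they give only indirect guidance. The expectation rests on compound 1, whose limit is > 20000 nM. The expected step is a step that the limit leaves unreadable from compound 1 to compound 4, with no change beyond the scatter and no direction foreseen in this assay. Compound 4 is estimated at 22000 nM, with an expected range from 10000 nM to 45000 nM, and a limit rather than a number is the likely report.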

Compound 4, half-maximal effective concentration: > 20000 nM
Compound 4 gave a limit, no number; the forecaster's own chance of this, stated with the estimate: 80%; the middle value lies beyond the limit too.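

Compound 1 and compound 4 each give only a limit in this assay, so no step can be read between them. The compounds shown leave open whether methyl in place of hydrogen on an aromatic carbon changes the read-out at all.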